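A few compounds are considered here, and "the series" means these few. Any claim that something is new, unique, unknown or untested is made for them only; others in the source may bear on it.

Three compounds have been measured in a functional assay on MCF7 cells (Homo sapiens) for inhibition, read by MTT assay, with a stated time of 72 h; a lower number here means a stronger inhibitor, a higher number a weaker inhibitor:
Compound 1, `Cc1ccccc1N1CCN(C(=S)N/N=C2\C(=O)Nc3ccc(Cl)cc32)CC1`, gives 10900 nM.
Compound 2, `O=C1Nc2ccc(Cl)cc2/C1=N/NC(=S)N1CCN(c2ccc(F)cc2)CC1`, gives 12300 nM.
Compound 3, `O=C1Nc2ccc(Cl)cc2/C1=N/NC(=S)N1CCN(c2ccc([N+](=O)[O-])cc2)CC1`, gives 20900 nM.

All three share the same core and differ only in the aryl group attached to the amine nitrogen of the six-membered ring with two nitrogens. The three measured steps are all small: a 1.1-fold higher number from compound 1 to compound 2 (0.05 log units; within the scatter), a 1.9-fold higher number from compound 1 to compound 3 (0.28 log units; within the scatter) and a 1.7-fold higher number from compound 2 to compound 3 (0.23 log units; within the scatter). Compound 3 thus stands together with compound 1 and compound 2; this assay does not separate any of the three.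

Compound 4, `O=C1Nc2ccc(Cl)cc2/C1=N/NC(=S)N1CCN(c2ccccc2[N+](=O)[O-])CC1`, has not yet been measured. It differs from compound 3 in one place: 2-nitrophenyl in place of 4-nitrophenyl on an amine nitrogen in a ring. The measured steps that bear on this are the aryl exchanges from compound 1 to compound 2 and from compound 2 to compound 3, each of which stayed within the scatter, and compound 1, whose ring is a 2-methylphenyl, also sits within the scatter of compound 3. For the measured compounds named here, no measured pair moves the same group from one ring position to another, so the direct effect of this rearrangement is untested. In this assay compound 4 is therefore expected to show no step beyond the scatter, a 1.2-fold lower number from compound 3 to compound 4 (0.09 log units; within the scatter). The estimate for compound 4 is 17000 nM, with a range from 7000 nM to 40000 nM.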

Compound 4, half-maximal inhibitory concentration: 7490 nM
Compound 4: the middle estimate sits 2.3-fold (0.36 log units) above what was measured, and the stated range covers the measured number.
By their numbers in this assay, from the lowest: compounds 4, 1, 2 and 3 (each within the scatter of the next, the first and the last beyond it).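

Moving the nitro group, so that 2-nitrophenyl replaces 4-nitrophenyl on the amine nitrogen of the ring, gives in this assay a 2.8-fold lower number from compound 3 to compound 4 (0.45 log units; beyond the scatter), the only step in this set that lies beyond the scatter, and it shows that the place of a group on this phenyl ring can change the number even when the atoms stay the same. The two other new steps, a 1.6-fold lower number from compound 2 to compound 4 (0.22 log units; within the scatter) and a 1.5-fold lower number from compound 1 to compound 4 (0.16 log units; within the scatter), stay within the scatter, so compound 4 is separated from compound 3 but not from compound 1 or compound 2. The data at hand offer no measurement that accounts for the step from compound 3 to compound 4.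

This is the only pair shown in which a group changes place on the phenyl ring, so it remains open whether moving the fluoro or the methyl group would give a step of similar size. Also open, as far as these compounds go, is how this assay would read a phenyl ring with no added group, or one carrying an amine or a carboxylic acid in place of the nitro group.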